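Swapping the charged ring end of a long side chain

The compounds below may be only part of what the source reports. "The series", "measured", "known", "first", "only" and "open" are said of these compounds alone.

Of the compounds shown here, three have been measured in an assay on LX2 cells for inhibition of COL1A1 promoter (Homo sapiens), read by a luciferase reporter, with a stated time of 24 h, tested at 20 uM; a lower number here means a weaker effect, a higher number a stronger effect of the compound at the concentration tested. Compound 1 `Cc1cc(OCCCCCCC[N+]2(C)CCCCC2)cc(-n2cc(C(=O)Nc3cc(F)cc(F)c3)c(=O)c3ccc(N(C)C)nc32)c1` gives 46.8% in this assay. Compound 2 `Cc1ccc(-n2cc(C(=O)Nc3cc(F)cc(F)c3)c(=O)c3ccc(N(C)C)nc32)cc1OCCCCCCC[N+]1(C)CCCCC1` is built from the same atoms joined differently, and the difference between the two cores is not broken down here; in this assay compound 2 gives 23.4%. Compound 3 `Cc1cc(OCCCCCCC[n+]2ccccc2)cc(-n2cc(C(=O)Nc3cc(F)cc(F)c3)c(=O)c3ccc(N(C)C)nc32)c1` differs from compound 1 by a group of 6 heavy atoms (5 carbon, 1 nitrogen; one six-membered aromatic ring with 1 hetero atom) in place of a group of 7 heavy atoms (6 carbon, 1 nitrogen; one six-membered non-aromatic ring with 1 hetero atom), on a saturated chain carbon, seven bonds along the chain from an oxygen on an aromatic ring, and in this assay compound 3 gives 7.7%, a drop described as a number 39.1 percentage points lower from compound 1 to compound 3 (beyond the scatter).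

Compound 4 `Cc1ccc(-n2cc(C(=O)Nc3cc(F)cc(F)c3)c(=O)c3ccc(N(C)C)nc32)cc1OCCCCCCC[n+]1ccccc1` is not yet measured. Among the measured compounds shown here, it differs from compound 2 by a group of 6 heavy atoms (5 carbon, 1 nitrogen; one six-membered aromatic ring with 1 hetero atom) in place of a group of 7 heavy atoms (6 carbon, 1 nitrogen; one six-membered non-aromatic ring with 1 hetero atom), on a saturated chain carbon, seven bonds along the chain from an oxygen on an aromatic ring, the same change as the one from compound 1 to compound 3, at the same place on the chain. Because the change from compound 1 to compound 3 gave a number 39.1 percentage points lower from compound 1 to compound 3 (beyond the scatter), and because compound 2 already starts from 23.4%, a comparable downward step is expected, though the read-out cannot fall far below zero. The expected step is a number 18.4 percentage points lower from compound 2 to compound 4 (beyond the scatter). For compound 4 the estimate in this assay is 5%, with a range from -10% to 20%.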

Compound 4, a percentage reported as inhibition, at one concentration (the size of the read-out at that concentration, not a potency): 39.7%
Compound 4: the middle estimate sits 34.7 percentage points below what was measured; measured number outside the range, above it.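

In this assay, replacing the six-membered non-aromatic ring at the end of the chain with the six-membered aromatic ring gave a number 16.3 percentage points higher from compound 2 to compound 4 (beyond the scatter). The change therefore did not carry over from one core to the other, and the step on the core of compound 1 did not even give the direction of the step on the core of compound 2: the same change on two cores in this assay, a number 39.1 percentage points lower (beyond the scatter) from compound 1 to compound 3 and a number 16.3 percentage points higher (beyond the scatter) from compound 2 to compound 4, 55.4 percentage points apart, beyond the scatter of two such steps Within these two pairs, the outcome of this swap depends on the core that carries it, but the result does not explain why the cores part ways, gives no potency since the read-out comes from a single concentration, and sets no rule for any other core.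

The compounds shown leave open whether a different charged end group on the same chain, such as a trimethylammonium group, would also behave differently on the two cores. They also leave open whether the split between the cores would persist with a shorter chain.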